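The source may hold more compounds than are shown below. What is called first, only, known or untested is meant among the compounds shown, and "the series" means these compounds.

Measured compounds in a functional assay on KG-1 cells (Homo sapiens) for cytotoxicity, read by luminescence and CellTiter-Glo, with a stated time of 3 days; a lower number here means a stronger inhibitor, a higher number a weaker inhibitor:
compound 1 `N#Cc1ccc(NC(=O)c2ccc3cccnc3c2O)c(Cl)c1` gives 3670 nM.
compound 2 `COc1cccc(C(=O)Nc2ccc(C#N)cc2)c1O` gives > 10000 nM, which is a limit of the assay and not a number.

Compound 2 therefore stands at the limit of > 10000 nM in this assay, at which 1 of the 2 values shown sits, and its standing can be read only as weak, with no number to set against compound 1. Compound 3 `N#Cc1ccc(NC(=O)c2cccc(F)c2O)cc1` differs from compound 2 by fluoro in place of methoxy on an aromatic carbon. Among the measured compounds shown here, no measured step of this kind exists in the set, so no shift beyond the scatter is expected in this assay, and compound 3 is expected to remain weak, most likely again at the limit. The estimate for compound 3 is 12000 nM, within 3500 nM to 40000 nM, so the expected step is a step that the limit leaves unreadable from compound 2 to compound 3.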

Compound 3, half-maximal inhibitory concentration: 9690 nM
For compound 3 the middle estimate is 1.2-fold (0.09 log units) above the measured one, and the stated range covers the measured number.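

In this assay, fluoro in place of methoxy on an aromatic carbon, ortho to a hydroxy group, gives an at least 1.0-fold lower number from compound 2 to compound 3 (0.01 log units; that floor lies within the scatter). Compound 2 carries only a limit of the assay, > 10000 nM, and not a number. Compound 3 gives this position its first number, 9690 nM. The true size of the step stays unreadable because one end of it is a limit: the limit of > 10000 nM in this assay, at which 1 of the 3 values shown sits.

Open, going by these compounds, is whether an amine or a longer alkoxy chain at this position would shift the number beyond the scatter. Also open, on these data alone, is how a chloro group at this position would read against compound 3.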